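The compounds below may be only part of what the source reports. "The series", "measured", "known", "first", "only" and "open" are said of these compounds alone.

Measured in a physicochemical assay for solubility, using the shake flask method, in simulated intestinal fluid, measured as kinetic solubility, with a stated time of 2 h, at 25 degrees C, at pH 6.5; a lower number here means a less soluble compound, a higher number a more soluble compound:
- Compound 1 `Cc1noc(-c2nc(C)c3c(c2N)C(=O)N(C(C)c2ccccc2)C3=O)n1`: 10900 nM
- Compound 2 `Cc1noc(-c2nc(C)c3c(c2N)C(=O)N(Cc2ccc(OC(F)F)cc2)C3=O)n1`: < 5000 nM

Only compound 1 has a true number here. Compound 2 gives no number in this assay, only (the limit of < 5000 nM in this assay, at which 1 of the 2 values shown sits). Its real value is therefore not known, and it cannot be placed exactly against compound 1.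

Compound 3 `Cc1noc(-c2nc(C)c3c(c2N)C(=O)N(Cc2ccc(C#N)cc2)C3=O)n1` is the same as compound 2 apart from one group. It has cyano in place of difluoromethoxy on an aromatic carbon, para to a large group (cyano in place of difluoromethoxy on an aromatic carbon).

Among the measured compounds shown here, no two measured compounds differ in just one place, so the data give no direct measure of what such a swap does. For the measured compounds named here, compound 1, at 10900 nM, shows only that a compound with this shared core can give a number in this assay. With so little to go on, a small upward move, not far beyond the usual scatter, is the cautious expectation, and another result at the limit remains quite possible. The expected step is an at least 1.2-fold higher number from compound 2 to compound 3 (0.07 log units; that floor lies within the scatter). Compound 3 is estimated at 6000 nM, within an expected range of 2000 nM to 15000 nM.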

Compound 3, solubility: < 5000 nM
Compound 3: no number, only a limit; the forecaster's own chance of this, stated with the estimate: 45%; middle value at least 1.2-fold (0.07 log units) away from the limit.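

Compound 3, like compound 2, stops at a limit in this assay, so cyano in place of difluoromethoxy on the aromatic carbon para to a large group still yields no true number, and the step between the two compounds cannot be read. Among the compounds shown here, the new compound does give the first readable step in this set: 4-cyanobenzyl in place of 1-phenylethyl on an amide-type nitrogen in a ring comes with an at least 2.1-fold lower number from compound 1 to compound 3 (0.33 log units; beyond the scatter). Compound 1 is thus the only one of the three with a true number, and the other two share a single limit: the limit of < 5000 nM in this assay, at which 2 of the 3 values shown sit.

Going by these compounds, how far below that limit compound 2 and compound 3 truly lie remains open, as does whether cyano and difluoromethoxy differ at all at this position. Also open, on these data alone, is what an amine or a carboxylic acid on the same aromatic carbon would give, and whether a cyano group on the phenyl ring of the 1-phenylethyl group would keep the result at a true number.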